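The compounds below may be only part of what the source reports. "The series", "measured", "known", "first", "only" and "open" are said of these compounds alone.

compound 1 `Cc1ccc(-c2cc(C(=O)N[C@H](C)c3ccc(C(F)(F)F)nc3)cc(C(C)(C)O)c2)nc1`: 95.2%
compound 2 `Cc1ccc(-c2cc(C(=O)N[C@H](C)c3ccc(C(F)(F)F)nc3)cc(-c3ncccc3F)c2)nc1`: 98.6%
compound 3 `C[C@@H](NC(=O)c1cc(-c2ccc(Cl)cc2)cc(C(C)(C)O)c1)c1ccc(C(F)(F)F)[n+]([O-])c1`: 97.4%

In an ADME assay on a cell-free system (plasma, Rattus norvegicus) for protein binding, compound 3 gives 97.4%, within the scatter of both compound 1 and compound 2. Compound 4 `C[C@@H](NC(=O)c1cc(-c2ccc(Cl)cn2)cc(C(C)(C)O)c1)c1ccc(C(F)(F)F)[n+]([O-])c1` differs from it at one place: 5-chloropyridin-2-yl in place of 4-chlorophenyl on an aromatic carbon. Among the compounds with values here, the only measured step, a 3.4-fold lower unbound fraction from compound 1 to compound 2 (0.54 log units; beyond the scatter), brings in a pyridinyl ring, but at another place and in exchange for 1-hydroxy-1-methylethyl, so it bears only loosely. Within the data shown here, no measured pair isolates the present exchange. A small move toward more free compound, not beyond the scatter, is expected, with the direction weakly supported: a 1.5-fold higher unbound fraction from compound 3 to compound 4 (0.19 log units; within the scatter). The estimate for compound 4 is 96%, with an expected range of 92.5% to 98.2%.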

Compound 4, plasma protein binding: 76.2%
Beside the measured number, compound 4's estimate is 6.0-fold (0.77 log units) (unbound fraction) below it, outside the stated range (below it).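

In this assay, this position on the aromatic carbon meta to a 1-hydroxy-1-methylethyl group proves sensitive to a single ring atom: 5-chloropyridin-2-yl in place of 4-chlorophenyl gives a 9.2-fold higher unbound fraction from compound 3 to compound 4 (0.96 log units; beyond the scatter) with one hydrogen-bond acceptor entering. The earlier step at another place, a 3.4-fold lower unbound fraction from compound 1 to compound 2 (0.54 log units; beyond the scatter), ran toward less free compound, so a pyridinyl ring has no single direction across these compounds. Nothing available accounts for the size of this step. Still open, going by these compounds, is whether the placement of the ring nitrogen matters, and whether an amine or a carboxylic acid on this ring would shift binding further.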